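A few compounds are considered here, and "the series" means these few. Any claim that something is new, unique, unknown or untested is made for them only; others in the source may bear on it.

Measured compounds in an ADME assay on MT4 cells (Homo sapiens) for cytotoxicity, read by MTT assay; a higher number here means that more compound is tolerated, a lower number that less compound is tolerated:
- compound 1 `Cc1cccc(C(=O)N(C(=S)OCCN2C(=O)c3ccccc3C2=O)c2ccc(Cl)cc2)c1`: 58000 nM
- compound 2 `O=C1c2ccccc2C(=O)N1CCOC(=S)N(C(=O)c1ccc(Br)cc1)c1ccc(Br)cc1`: 73000 nM
- compound 3 `Cc1ccc(N(C(=O)c2ccccc2C)C(=S)OCCN2C(=O)c3ccccc3C2=O)cc1`: > 100000 nM

Compound 1 gives the lower of the two numbers in this assay, but compound 2 lies within the scatter of it, so no order between these two is read. For compound 3 the result is a limit of the assay rather than a number, as noted in the limit of > 100000 nM in this assay, at which 1 of the 3 values shown sits.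

Compound 4 `O=C1c2ccccc2C(=O)N1CCOC(=S)N(C(=O)c1ccc(F)c(F)c1)c1ccc(Cl)cc1` has not been measured. Against compound 1 it differs in one place: 3,4-difluorophenyl in place of 3-methylphenyl on a carbonyl carbon. Among the measured compounds shown here, no step between measured compounds covers a change at this position, so the series itself gives no measured size for it. What the numbers of compound 1 and compound 2 show is that the shared core tolerates variation at both aryl groups without moving beyond the scatter. On that basis the step from compound 1 to compound 4 is expected to be none beyond the scatter, with a 1.1-fold higher number from compound 1 to compound 4 (0.05 log units; within the scatter) as the anticipated change in this assay. Compound 4 is accordingly estimated at 65000 nM, within a range from 30000 nM to 130000 nM.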

Compound 4, half-maximal cytotoxic concentration: 52000 nM
Compound 4: middle estimate off by 1.3-fold (0.10 log units), on the high side, and the stated range covers the measured number.
By their numbers in this assay, from the lowest: compounds 4, 1 and 2 (each within the scatter of the next). At a limit, above all of these: compound 3.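

The position on a carbonyl carbon whose other neighbour is an amide-type nitrogen now has its first measured step in this assay: 3,4-difluorophenyl in place of 3-methylphenyl gives a 1.1-fold lower number from compound 1 to compound 4 (0.05 log units; within the scatter) with the rest of compound 1 unchanged. Among the compounds shown here, at this position, then, an aromatic ring carrying two fluorines and one carrying a methyl group read alike in this assay, which the earlier compounds, differing in more than one place, could not show. Nothing measured here bears on why the two groups read alike.

On these data alone, whether an amine, a carboxylic acid or a longer chain at this position would also stay within the scatter remains open. Compound 3 still gives a limit of the assay and not a number: the limit of > 100000 nM in this assay, at which 1 of the 4 values shown sits.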